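A few compounds are considered here, and "the series" means these few. Any claim that something is new, unique, unknown or untested is made for them only; others in the source may bear on it.

Working notes on the series, read in a functional assay on MCF7 cells (Homo sapiens) for inhibition, read by MTT assay, with a stated time of 48 h; a higher number here means a weaker inhibitor, a lower number a stronger inhibitor. Compound 1 `Brc1ccc2[nH]cc(C(c3ccccc3)c3c[nH]c4ccc(Br)cc34)c2c1` gives 5500 nM, compound 2 `COc1ccc(OC)c(C(c2c[nH]c3ccc(Br)cc23)c2c[nH]c3ccc(Br)cc23)c1` gives 2800 nM, and compound 3 `Brc1ccc(C(c2c[nH]c3ccc(Br)cc23)c2c[nH]c3ccc(Br)cc23)cc1` gives 3200 nM. Compound 3 stands level with the other two, and the remaining step, a 2.0-fold lower number from compound 1 to compound 2 (0.29 log units; within the scatter), also stays inside the scatter.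

The next comparison is compound 4 `O=[N+]([O-])c1ccc(C(c2c[nH]c3ccc(Br)cc23)c2c[nH]c3ccc(Br)cc23)cc1`, which carries nitro in place of bromo on an aromatic carbon, para to a large group: nitro in place of bromo on an aromatic carbon. Within the data shown here, no measured compound carries nitro, so the evidence is indirect. Among the measured compounds shown here, two measured steps touch the same group: bromo in place of hydrogen gave a 1.7-fold lower number from compound 1 to compound 3 (0.24 log units; within the scatter), and 4-bromophenyl in place of 2,5-dimethoxyphenyl gave a 1.1-fold higher number from compound 2 to compound 3 (0.06 log units; within the scatter). Neither step leaves the scatter, so no step beyond the scatter is expected in this assay, and no direction is favoured. The estimated step is a 1.1-fold lower number from compound 3 to compound 4 (0.03 log units; within the scatter). For compound 4 the expected value is 3000 nM, with an estimated range of 1300 nM to 7000 nM.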

Compound 4, half-maximal inhibitory concentration: 3100 nM
Beside the measured number, compound 4's estimate is 1.0-fold (0.01 log units) below it; low and high end bracket the measured number.
By their numbers in this assay, from the lowest: compounds 2, 4, 3 and 1 (each within the scatter of the next).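

In this assay, the aromatic carbon para to a large group takes nitro in place of bromo, bringing in hydrogen-bond acceptors where bromo had none, yet the comparison reads as a 1.0-fold lower number from compound 3 to compound 4 (0.01 log units; within the scatter) and gives no separation between the two groups. The other comparisons stay inside the scatter too, with a 1.1-fold higher number from compound 2 to compound 4 (0.04 log units; within the scatter) for 4-nitrophenyl in place of 2,5-dimethoxyphenyl and a 1.8-fold lower number from compound 1 to compound 4 (0.25 log units; within the scatter) for nitro in place of hydrogen, so no group shown on this ring moves the number beyond the scatter. Nothing at hand bears on why these numbers sit so close.

Going by these compounds, whether an amine or a carboxylic acid at this position would leave the scatter stays open. Also open is what the bromo groups on the shared core contribute, as every compound shown keeps them.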